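This account rests on a few compounds, and the source may have more. Where it says the series, first, only, none or still open, it means among the compounds named here.

Of the compounds shown here, three carrying the same cyanopyrrolidine amide have been measured in an assay on the whole organism (plasma, strain Sprague-Dawley) for inhibition of Dipeptidyl peptidase 4 (Rattus norvegicus), with a stated time of 6 h, at a dose of 1 mg/kg by the oral route; on this read-out higher numbers stand for more inhibition at the one dose given (going by the name of the read-out) and lower numbers for less inhibition. Compound 1 `CCC[C@@H]1CN[C@H](C(=O)N2CCC[C@H]2C#N)C1` gives 50%. Compound 2 `N#C[C@@H]1CCCN1C(=O)[C@@H]1C[C@H](C(=O)N2CCCCCCC2)CN1` gives 63%, and compound 3 `N#C[C@@H]1CCCN1C(=O)[C@@H]1C[C@H](C(=O)N2CCCCCC2)CN1` gives 68%. For the measured compounds named here, compound 3 therefore sits well above compound 1, while its value and that of compound 2 lie within the usual scatter of each other; the one recorded step, a number 5 percentage points higher from compound 2 to compound 3 (within the scatter), shows that trading one saturated ring amide for a smaller one left the read-out essentially unchanged.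

Compound 4 `CNC(=O)[C@@H]1CN[C@H](C(=O)N2CCC[C@H]2C#N)C1` differs from compound 3 by methylamino in place of azepan-1-yl on a carbonyl carbon. Going by the values given here, no measured step covers this change directly. The step between compound 2 and compound 3 bears on it only loosely, since it also shrinks the amide, and it was flat. Compound 1, which carries a plain propyl chain at the same position of the shared core, stands lower, so the amide portion appears to matter. On this basis compound 4 is expected to show a modest drop, a number 13 percentage points lower from compound 3 to compound 4 (beyond the scatter), in this assay, with an estimated value of 55% and a range of 35% to 75%.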

Compound 4, a percentage reported as inhibition, in the whole organism at one dose (the size of the read-out at that dose, not a potency): 75%
For compound 4 the middle estimate is 20 percentage points below the measured one; measured number inside the range.
By their numbers in this assay, from the lowest: compound 1; then compounds 2, 3 and 4 (each within the scatter of the next, the first and the last beyond it).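

At this carbonyl carbon in this assay, a large saturated ring amide is not needed to keep the read-out: methylamino in place of azepan-1-yl gives a number 7 percentage points higher from compound 3 to compound 4 (within the scatter) and so does not fall short of the seven-membered ring. The same small group set against the eight-membered ring amide gives a number 12 percentage points higher from compound 2 to compound 4 (beyond the scatter) and methylcarbamoyl in place of propyl on a saturated ring carbon gives a number 25 percentage points higher from compound 1 to compound 4 (beyond the scatter) as the widest step among these compounds, so a small amide here stands clear of both. No measurement shown gives a reason for these steps. What the compounds shown leave open is whether the amide hydrogen of methylamino matters, as a dimethylamino amide would test. They also leave open how a primary carboxamide or a carboxylic acid would read at this place.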